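The source may report more compounds than this note shows. Statements on the series, on what has been measured and on what is new or still open speak of the compounds shown alone.

Among the compounds with values here, in a functional assay on BXPC-3 cells (Homo sapiens) for inhibition, read by MTT assay, with a stated time of 7 days (a lower number here means a stronger inhibitor, a higher number a weaker inhibitor), compound 1 (`CCN(CC)S(=O)(=O)c1ccc(S(=O)(=O)N2CCC[C@@H](C(=O)N3CCC(O)CC3)C2)cc1`) gives 4710 nM, the highest of the three numbers measured so far. Compound 2 (`CCC(CC)S(=O)(=O)c1ccc(S(=O)(=O)N2CCC[C@@H](C(=O)N3CCC(F)(F)CC3)C2)cc1`) gives 40 nM, and compound 3 (`O=C([C@@H]1CCCN(S(=O)(=O)c2ccc(S(=O)(=O)C3COC3)cc2)C1)N1CCC(F)(F)CC1`) gives 361 nM. The change to compound 4 (`CCN(CC)S(=O)(=O)c1ccc(S(=O)(=O)N2CCC[C@@H](C(=O)N[C@H]3CC[C@@H](OC)CC3)C2)cc1`) is (4-methoxycyclohexyl)amino in place of 4-hydroxypiperidin-1-yl on a carbonyl carbon.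

Within the data shown here, the only measured single-place step, a 9.0-fold higher number from compound 2 to compound 3 (0.96 log units; beyond the scatter), lies on a sulfonyl sulfur, so it sets a scale for the series but does not measure this change. Compound 1 and compound 2 differ in more than one place, so their gap cannot be assigned to the carbonyl substituent alone. Among the measured compounds shown here, no measured compound carries the (4-methoxycyclohexyl)amino group.

With compound 1 at 4710 nM, the top of the measured range, a modest move toward a lower number is expected, though with wide uncertainty. The expected step is a 5.2-fold lower number from compound 1 to compound 4 (0.72 log units; beyond the scatter). For compound 4, the estimate is 900 nM, with an expected range of 200 nM to 4000 nM.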

Compound 4, half-maximal inhibitory concentration: 2150 nM
Estimate against measurement, compound 4: 2.4-fold (0.38 log units) below, within the range that was stated.
By their numbers in this assay, from the lowest: compound 2; then compound 3; then compound 4; then compound 1.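

At the carbonyl carbon, this assay now gives a single-place reading, a 2.2-fold lower number from compound 1 to compound 4 (0.34 log units; beyond the scatter), so replacing 4-hydroxypiperidin-1-yl with (4-methoxycyclohexyl)amino changes the number only modestly. The change replaces a ring with a hetero atom by a ring of carbon only and adds heavy atoms, while the hydrogen-bond donor and acceptor counts stay the same. No supporting data explain the step.

The compounds shown leave open which part of the change carries the step: a (4-hydroxycyclohexyl)amino or a 4-methoxypiperidin-1-yl group on the same carbonyl carbon would separate the ring change from the change at the oxygen. Also open, on these data alone, is whether (4-methoxycyclohexyl)amino gives a similar step when pentan-3-yl stands on the sulfonyl sulfur.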